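Methyl for chloro on the sulfonyl ring, second time

The source may hold more compounds than are shown below. What is called first, only, known or untested is meant among the compounds shown, and "the series" means these compounds.

The measured compounds:

compound 1, `COc1ccc(Cl)cc1C(C)NC(=O)N(C)S(=O)(=O)c1ccc(Cl)cc1`, 20000 nM
compound 2, `COc1ccc(Cl)cc1C(C)NC(=O)N(C)S(=O)(=O)c1ccc(C)cc1`, 13800 nM
compound 3, `CC(NC(=O)N(C)S(=O)(=O)c1ccc(Cl)cc1)c1ccccc1OCc1ccccc1`, 38400 nM

Of the compounds shown here, three have been tested in a functional assay on thoracic aorta (Rattus norvegicus, strain Wistar), with a stated time of 15 min; a lower number here means that less compound is needed, a higher number that more compound is needed for the effect. Compound 1 gives 20000 nM, and compound 2 gives 13800 nM in this assay. Compound 3 gives 38400 nM in this assay; its value lies within the scatter of that of compound 1, but beyond the scatter of that of compound 2.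

Compound 1 and compound 2 share a core and differ in a single place, (methyl in place of chloro on an aromatic carbon). This change gave a 1.4-fold lower number from compound 1 to compound 2 (0.16 log units; within the scatter). Compound 3 differs from compound 1 by a larger part of the molecule; the difference between the two cores is not broken down here.

Compound 4, `Cc1ccc(S(=O)(=O)N(C)C(=O)NC(C)c2ccccc2OCc2ccccc2)cc1`, has not yet been measured in this assay. It is related to compound 3 by the same change that relates compound 2 to compound 1, (methyl in place of chloro on an aromatic carbon). The surroundings of the change read the same in both pairs.

Going by the values given here, since the one example seen, from compound 1 to compound 2, stayed within the scatter, compound 4 is expected to land close to compound 3, with the estimated step of a 1.4-fold lower number from compound 3 to compound 4 (0.15 log units; within the scatter). In this assay compound 4 is therefore expected to give about 27000 nM, between roughly 12000 nM and 60000 nM; this rests on a single prior example, so the range is kept wide.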

Compound 4, half-maximal effective concentration: 31000 nM
For compound 4 the middle estimate is 1.1-fold (0.06 log units) below the measured one, within the range that was stated.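

In this assay, the change from (4-chlorophenyl)sulfonyl to (4-methylphenyl)sulfonyl on the core of compound 3 gave a 1.2-fold lower number from compound 3 to compound 4 (0.09 log units; within the scatter), so here too the swap of chloro for methyl left the number within the usual spread of repeat measurements. Set beside the earlier step, the change carried over from one core to the other without a difference that can be told apart: the same change on two cores in this assay, a 1.4-fold lower number (0.16 log units; within the scatter) from compound 1 to compound 2 and a 1.2-fold lower number (0.09 log units; within the scatter) from compound 3 to compound 4, 1.2-fold (0.07 log units) apart, within the scatter of two such steps. This shows that, on these two cores, the exchange of chloro for methyl behaves alike and moves the number little, but with both steps inside the scatter it does not establish that methyl truly lowers the number, and two cores cannot show how the change would read on any other core in the series.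

The compounds shown leave open what an amine, a carboxylic acid or a longer chain would do in place of the chloro or methyl on this ring. They also leave open whether any group at that place can move the number in this assay by more than the scatter, since chloro and methyl alone do not answer that.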